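Lengthening an ester chain on an amide series

The source may report more compounds than this note shows. Statements on the series, on what has been measured and on what is new or still open speak of the compounds shown alone.

Of the compounds shown here, three have been measured in a functional assay on NB-4 cells (Homo sapiens) for inhibition, read by MTT assay, with a stated time of 48 h; on this read-out lower numbers stand for stronger inhibition and higher numbers for weaker inhibition. Compound 1 `Cc1cc2c(cc1C(=O)c1ccc(C(=O)OCCCCOC(=O)c3ccc(C(=O)Nc4ccc5c(c4)C(C)(C)CCC5(C)C)cc3)cc1)C(C)(C)CCC2(C)C` gives 147000 nM, compound 2 `CCCC(=O)OCCOC(=O)c1ccc(C(=O)Nc2ccc3c(c2)C(C)(C)CCC3(C)C)cc1` gives 11000 nM, and compound 3 `C=C(c1ccc(C(=O)OCCCCOC(=O)c2ccc(C(=O)Nc3ccc4c(c3)C(C)(C)CCC4(C)C)cc2)cc1)c1cc2c(cc1C)C(C)(C)CCC2(C)C` gives 650000 nM. Compound 2 thus has the lowest number of the three, and both gaps lie beyond the scatter. Compound 4 `CCCC(CCC)C(=O)OCCOC(=O)c1ccc(C(=O)Nc2ccc3c(c2)C(C)(C)CCC3(C)C)cc1` differs from compound 2 by a single change: 1-propylbutyl in place of propyl on a carbonyl carbon. For the measured compounds named here, no measured pair shows the effect of growing this chain, so the expectation rests only on the position of compound 2. In this assay the step is expected to be small, a 1.4-fold higher number from compound 2 to compound 4 (0.13 log units; within the scatter), within the scatter or slightly weaker. Compound 4 is therefore estimated at 15000 nM, with a range from 5000 nM to 50000 nM.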

Compound 4, half-maximal inhibitory concentration: > 1000000 nM
Compound 4 gave a limit, no number; the forecaster's own chance of this, stated with the estimate: 10%; middle value at least 66-fold (1.82 log units) from the limit.
By their numbers in this assay, from the lowest: compound 2; then compound 1; then compound 3. At a limit, above all of these: compound 4.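

For the compounds shown here, this is the first pair that differs in one place, and it shows that the read-out is highly sensitive to the group on this carbonyl carbon. In this assay, 1-propylbutyl in place of propyl gives an at least 90-fold higher number from compound 2 to compound 4 (1.95 log units; beyond the scatter), so this chain cannot be enlarged freely. Compound 4 gives no number, only a limit: the limit of > 1000000 nM in this assay, at which 1 of the 4 values shown sits.

Going by these compounds, it remains open whether the branching or the number of carbons matters more. A straight heptyl chain or a small isopropyl group on the same carbonyl carbon could separate the two.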